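Series notes: cytotoxicity limits and one open compound

The source may report more compounds than this note shows. Statements on the series, on what has been measured and on what is new or still open speak of the compounds shown alone.

Measured so far in a functional assay on HepG2 cells (Homo sapiens) for cytotoxicity, read by MTT assay, with a stated time of 48 h; on this read-out higher numbers stand for weaker inhibition and lower numbers for stronger inhibition:
- compound 1 `C#CCSc1nnc(C)n1N1C(=O)c2ccccc2C1=O` gives > 200000 nM, a limit of the assay.
- compound 2 `Cc1nnc(SCc2ccccc2Cl)n1N1C(=O)c2ccccc2C1=O` gives > 200000 nM, a limit of the assay.
- compound 3 `COc1cc(-c2nnc(SCc3ccccc3Cl)n2N2C(=O)c3ccccc3C2=O)cc(OC)c1OC` gives > 200000 nM, a limit of the assay.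

All three values sit at the limit of > 200000 nM in this assay, at which 3 of the 3 values shown sit, so no number has been read for any of them. Compound 1 differs from compound 2 by ethynyl in place of 2-chlorophenyl on a saturated chain carbon bound to a sulfur, and on this pair a step that the two limits leave unreadable from compound 2 to compound 1. Compound 3 differs from compound 2 by 3,4,5-trimethoxyphenyl in place of methyl on an aromatic carbon, which is also how the cores of the two pairs differ; on this pair a step that the two limits leave unreadable from compound 2 to compound 3.

Still to be measured is compound 4 `C#CCSc1nnc(-c2cc(OC)c(OC)c(OC)c2)n1N1C(=O)c2ccccc2C1=O`. Among the measured compounds shown here, it differs from compound 3 by ethynyl in place of 2-chlorophenyl on a saturated chain carbon bound to a sulfur, the same change as the one from compound 2 to compound 1, at the same place. That earlier step is not readable because of the limit of > 200000 nM in this assay, at which 3 of the 3 values shown sit, and nothing beyond it is available. The step from compound 3 to compound 4 is expected to be a step that the limit leaves unreadable from compound 3 to compound 4, resting on (the limit of > 200000 nM in this assay, at which 3 of the 3 values shown sit), at which both measured compounds carrying this change sit. Compound 4 is therefore expected to give 250000 nM in this assay, estimated between 80000 nM and 1000000 nM, most likely as a limit again rather than a number.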

Compound 4, half-maximal inhibitory concentration: > 200000 nM
Compound 4 ended at the assay's limit; the forecaster's own chance of this, stated with the estimate: 85%; the middle value does not contradict the limit.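

No step can be read from compound 3 to compound 4, and compound 4 adds no number to the series: the limit of > 200000 nM in this assay, at which 4 of the 4 values shown sit.

The compounds shown leave open whether ethynyl or 2-chlorophenyl on the chain, or methyl or 3,4,5-trimethoxyphenyl on the aromatic carbon, makes any difference in this assay.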